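From a Methylphenyl to a Pyridinyl End Group

The compounds below may be only part of what the source reports. "The series", "measured", "known", "first", "only" and "open" are said of these compounds alone.

Compound 1 `C=CCOc1cc(OC)c(C(=O)/C=C/c2ccc(C)cc2)c(OCC=C)c1` carries a 4-methylphenyl group at the far end of its double-bonded chain and was tested in an ADME assay on Vero cells (Chlorocebus sabaeus) for cytotoxicity, read by MTT assay (a higher number here means a weaker inhibitor, a lower number a stronger inhibitor), where compound 1 gives 211000 nM. Within the data shown here, that is the highest of the two numbers known so far. Among the measured compounds shown here, compound 2 `C=CCOc1cc(OC)c(C(=O)/C=C/c2ccc(O)cc2)c(OCC=C)c1` gives 76400 nM in this assay, and the step between them, a 2.8-fold lower number from compound 1 to compound 2 (0.44 log units; beyond the scatter), is the only measured step that touches this end of the molecule. Compound 3 `C=CCOc1cc(OC)c(C(=O)/C=C/c2ccc(O)c(OC)c2)c(OCC=C)c1` was also prepared, but in this assay compound 3 stands at "not determined" (no result reported), so no single number is known for it.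

Compound 4 `C=CCOc1cc(OC)c(C(=O)/C=C/c2ccccn2)c(OCC=C)c1` differs from compound 1 at that same end: pyridin-2-yl in place of 4-methylphenyl on a double-bonded chain carbon bound to a double-bonded chain carbon. For the measured compounds named here, no measured step exchanges the whole ring, so the single step of a 2.8-fold lower number from compound 1 to compound 2 (0.44 log units; beyond the scatter) serves only as a rough guide; it shows that a change on that ring moved the number modestly, and downward. A step of similar size and direction is expected here. Compound 4 is therefore estimated at 150000 nM, most likely between 55000 nM and 400000 nM, which corresponds to an expected step of a 1.4-fold lower number from compound 1 to compound 4 (0.15 log units; within the scatter).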

Compound 4, half-maximal inhibitory concentration: 2800 nM
Compound 4: the middle estimate sits 54-fold (1.73 log units) above what was measured, and the stated range ends above it.
By their numbers in this assay, from the lowest: compound 4; then compound 2; then compound 1.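

Replacing the whole end ring changes the result far more in this assay than the earlier hydroxy-for-methyl change on that ring, which gave a 2.8-fold lower number from compound 1 to compound 2 (0.44 log units; beyond the scatter). Pyridin-2-yl gives a 75-fold lower number from compound 1 to compound 4 (1.88 log units; beyond the scatter) when it replaces 4-methylphenyl and a 27-fold lower number from compound 2 to compound 4 (1.44 log units; beyond the scatter) when it replaces 4-hydroxyphenyl, so compound 4 has the lowest number of the three and this position is far more sensitive to the identity of the ring than the first step suggested. Nothing available explains this large drop.

As far as these compounds go, the step to compound 4 both brings a ring nitrogen in and takes the methyl group away, so the share of each remains unknown. An unsubstituted phenyl ring would help separate the two, and pyridin-3-yl or pyridin-4-yl would show whether the drop is specific to pyridin-2-yl.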